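From Dimethylamino to Dihydroxy in a Cytotoxicity Series

The compounds below may be only part of what the source reports. "The series", "measured", "known", "first", "only" and "open" are said of these compounds alone.

Of the compounds shown here, three sharing one core have been tested in an ADME assay on HEK293 cells (Homo sapiens) for cytotoxicity, read by MTT assay, with a stated time of 48 h; on this read-out higher numbers stand for weaker inhibition and lower numbers for stronger inhibition. Compound 1 `O=C1/C(=C\c2ccc(Cl)cc2)S/C(=N/c2ccccc2)N1Cc1ccncc1`, which carries a chloro group, gives 42300 nM. Compound 2 `O=C1/C(=C\c2ccc([N+](=O)[O-])cc2)S/C(=N/c2ccccc2)N1Cc1ccncc1`, with nitro in its place, gives 250000 nM. Compound 3 `CN(C)c1ccc(/C=C2/S/C(=N/c3ccccc3)N(Cc3ccncc3)C2=O)cc1`, with dimethylamino there, gives 122000 nM, the second highest of the three numbers.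

The next structure is compound 4 `O=C1/C(=C\c2ccc(O)c(O)c2)S/C(=N/c2ccccc2)N1Cc1ccncc1`, where 3,4-dihydroxyphenyl takes the place of 4-(dimethylamino)phenyl on a double-bonded chain carbon bound to a double-bonded ring carbon: 3,4-dihydroxyphenyl in place of 4-(dimethylamino)phenyl on a double-bonded chain carbon bound to a double-bonded ring carbon. Among the compounds with values here, no measured step makes this exact exchange, so the nearest guides are single-group swaps on an aromatic carbon. These are modest: a 5.9-fold higher number from compound 1 to compound 2 (0.77 log units; beyond the scatter), a 2.9-fold higher number from compound 1 to compound 3 (0.46 log units; beyond the scatter) and a 2.0-fold lower number from compound 2 to compound 3 (0.31 log units; beyond the scatter). A modest step is therefore expected here too. Its direction is uncertain, but a lower number seems likelier, given that compound 3 at 122000 nM sits in the upper part of the measured span. The expected change is a 1.9-fold lower number from compound 3 to compound 4 (0.27 log units; within the scatter). Compound 4 is estimated at 65000 nM, with an expected range of 22000 nM to 190000 nM.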

Compound 4, half-maximal inhibitory concentration: 230000 nM
Compound 4: the middle estimate sits 3.5-fold (0.55 log units) below what was measured; the measured number lies above the stated range.
By their numbers in this assay, from the lowest: compound 1; then compounds 3, 4 and 2 (each within the scatter of the next, the first and the last beyond it).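

In this assay, within the data shown here, this exchange replaces the whole aromatic group on a double-bonded chain carbon bound to a double-bonded ring carbon, and it brings in hydrogen-bond donors for the first time. It gives a 1.9-fold higher number from compound 3 to compound 4 (0.28 log units; within the scatter) and a 1.1-fold lower number from compound 2 to compound 4 (0.04 log units; within the scatter) so compound 4 cannot be told apart from either neighbour, even though those two differ from each other by just beyond the scatter. Only the chloro compound stands apart, with a 5.4-fold higher number from compound 1 to compound 4 (0.74 log units; beyond the scatter) and no measurement here explains that separation.

A single hydroxyl or a methoxy group on the same aromatic ring could show whether one oxygen group is enough to place a compound near compound 4 or nearer compound 1. A bromo or fluoro group in place of the chloro would test whether the low number of compound 1 is specific to chlorine.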